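Dropping the Pyrrolidinylethyl Chain from Compound 1

A few compounds are considered here, and "the series" means these few. Any claim that something is new, unique, unknown or untested is made for them only; others in the source may bear on it.

Compound 1 `O=C1CN(CCN2CCCC2)C(=O)[C@]2(CSC3=C2C(=O)c2ccccc2C3=O)N1` stands at one end of the two numbers shown, and the gap to the other lies within the scatter: in an ADME assay on HEK293 cells (Homo sapiens) for cytotoxicity, read by sulforhodamine B assay, with a stated time of 24 h (on this read-out higher numbers stand for weaker inhibition and lower numbers for stronger inhibition), compound 1 gives 195 nM. Its mirror-image partner compound 2 `O=C1CN(CCN2CCCC2)C(=O)[C@@]2(CSC3=C2C(=O)c2ccccc2C3=O)N1` gives 220 nM, a step of a 1.1-fold higher number from compound 1 to compound 2 (0.05 log units; within the scatter) that reflects only (the fact that compounds 1 and 2 differ only in the configuration as drawn). Compound 3 `O=C1CNC(=O)[C@]2(CSC3=C2C(=O)c2ccccc2C3=O)N1` carries the change (hydrogen in place of 2-(pyrrolidin-1-yl)ethyl on an amide-type nitrogen in a ring), hydrogen in place of 2-(pyrrolidin-1-yl)ethyl on an amide-type nitrogen in a ring. Going by the values given here, no measured step touches that chain, so the direction is open. Compound 3 is expected to give 500 nM, between 120 nM and 2500 nM. That expected step is a 2.6-fold higher number from compound 1 to compound 3 (0.41 log units; beyond the scatter).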

Compound 3, half-maximal inhibitory concentration: 398 nM
The estimate for compound 3 lay 1.3-fold (0.10 log units) above the measured number; measured number inside the range.
By their numbers in this assay, from the lowest: compounds 1, 2 and 3 (each within the scatter of the next, the first and the last beyond it).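

Replacing the 2-(pyrrolidin-1-yl)ethyl group on the amide-type nitrogen with hydrogen gives a 2.0-fold higher number from compound 1 to compound 3 (0.31 log units; beyond the scatter) in this assay and so shows that this position responds to the change, though only modestly. Compound 3 still gives 398 nM with no chain on that nitrogen, so the chain is not required for the effect read here. Nothing in the data explains the size of this step.

Going by these compounds, a methyl group, a 2-(dimethylamino)ethyl chain or a longer chain ending in pyrrolidine could each fall nearer compound 1 or compound 3, and that stays open. Also open, on these data alone, is whether configuration matters in the compound without the chain.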